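The source may report more compounds than this note shows. Statements on the series, on what has been measured and on what is new or still open speak of the compounds shown alone.

Three close relatives share one core, a methyl-tetrazole sulfide linked through an acetohydrazide to a benzylidene ring, and differ only in one substituent on that ring. Compound 1 `Cn1nnnc1SCC(=O)N/N=C/c1ccccc1` carries hydrogen there; in an ADME assay on NIH3T3 cells (Mus musculus) for cytotoxicity, read by XTT assay, with a stated time of 24 h (a lower number here means a stronger inhibitor, a higher number a weaker inhibitor), compound 1 gives 9700000 nM. Compound 2 `Cn1nnnc1SCC(=O)N/N=C/c1cccc([N+](=O)[O-])c1` carries a nitro group, and in this assay compound 2 gives 2000000 nM. Compound 3 `Cn1nnnc1SCC(=O)N/N=C/c1cccc(Br)c1` carries bromo, and in this assay compound 3 gives 316000 nM, the lowest of the three numbers, with the step of a 31-fold lower number from compound 1 to compound 3 (1.49 log units; beyond the scatter) and the step of a 6.3-fold lower number from compound 2 to compound 3 (0.80 log units; beyond the scatter) both beyond the scatter.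

Compound 4 `Cc1cccc(/C=N/NC(=O)CSc2nnnn2C)c1` is the next relative. Its change is methyl in place of bromo on an aromatic carbon, on an aromatic carbon of a six-membered aromatic ring of carbon only, meta to a large group. The bromo group is thus removed again. The measured steps say that putting bromo in gave the large lowering a 31-fold lower number from compound 1 to compound 3 (1.49 log units; beyond the scatter) and the modest lowering a 6.3-fold lower number from compound 2 to compound 3 (0.80 log units; beyond the scatter); putting nitro in gave only a 4.9-fold lower number from compound 1 to compound 2 (0.69 log units; beyond the scatter). Taking bromo out for methyl is therefore expected to raise the number in this assay, by roughly a 4.7-fold higher number from compound 3 to compound 4 (0.68 log units; beyond the scatter), landing between the hydrogen and bromo compounds. For compound 4 the estimated value in this assay is 1500000 nM, with a likely range from 400000 nM to 6000000 nM.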

Compound 4, half-maximal inhibitory concentration: 6250000 nM
For compound 4 the middle estimate is 4.2-fold (0.62 log units) below the measured one, and the stated range ends below it.
By their numbers in this assay, from the lowest: compound 3; then compound 2; then compounds 4 and 1 (each within the scatter of the next).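

In this assay, methyl in place of bromo at this ring position takes back most of the lowering that bromo brought, with a 20-fold higher number from compound 3 to compound 4 (1.30 log units; beyond the scatter), while a 1.6-fold lower number from compound 1 to compound 4 (0.19 log units; within the scatter) leaves compound 4 within the scatter of compound 1, so methyl and hydrogen cannot be told apart here. The position therefore does not respond to just any group in place of hydrogen: among these four compounds, bromo and nitro give clearly lower numbers than methyl, and the nitro compound stays apart from the methyl compound, with a 3.1-fold higher number from compound 2 to compound 4 (0.49 log units; beyond the scatter). Nothing available here accounts for why bromo and methyl, each a single heavy atom, behave so differently in this assay.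

On these data alone, the four compounds cover only hydrogen and three groups at one place on the ring, so it remains open whether the low number belongs to bromo alone or is shared by chloro or iodo. As far as these compounds go, it also remains open where an amine, a carboxylic acid or a longer chain at this place would fall, and whether bromo would give the same lowering elsewhere on the ring.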